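Bromo for Methyl on the Aromatic Carbon of Compound 3

A few compounds are considered here, and "the series" means these few. Any claim that something is new, unique, unknown or untested is made for them only; others in the source may bear on it.

Compound 1, `O=C(Nc1ncccc1N1CCN(C(=O)Cn2cnc3cccnc32)CC1)c1cccc(Cl)c1`, in a functional assay on CHO-K1 cells for antagonist activity at C-X-C chemokine receptor type 3 (Homo sapiens), read by FLIPR, with a stated time of 10 min; a lower number here means a stronger inhibitor, a higher number a weaker inhibitor: 177 nM
Compound 2, `O=C(Cn1cnc2cccnc21)N1CCN(c2ncccc2-c2nc3ccccc3[nH]2)CC1`, in this assay: 496 nM
Compound 3, `Cc1nc(-c2nc3ccccc3[nH]2)c(N2CCN(C(=O)Cn3cnc4cccnc43)[C@H](C)C2)s1`, in this assay: 9 nM

Among these three measured compounds, compound 3 gives the lowest number in this assay. Its nearest neighbour is compound 1, whose value stands a good deal higher, beyond the scatter; compound 2 lies further still, also beyond the scatter. Compound 3 thus stands clearly apart from the other two.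

The unmeasured compound 4, `C[C@@H]1CN(c2sc(Br)nc2-c2nc3ccccc3[nH]2)CCN1C(=O)Cn1cnc2cccnc21`, is derived from compound 3 by a single change: bromo in place of methyl on an aromatic carbon. Nothing else in the molecule moves, and the 1H-benzimidazol-2-yl group and the large group on the same five-membered ring are unchanged.

No pair of measured compounds shows this swap, so there is no shown step on which to rest a direction. With one heavy atom leaving and one heavy atom entering, and no change in donors, acceptors or charge, the step is expected to be small, with no direction beyond the scatter. The estimated step from compound 3 to compound 4 in this assay is a 1.1-fold higher number from compound 3 to compound 4 (0.05 log units; within the scatter). Compound 4 is expected to give about 10 nM in this assay, within a range from 3 nM to 35 nM.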

Compound 4, half-maximal inhibitory concentration: 2.8 nM
For compound 4 the middle estimate is 3.6-fold (0.55 log units) above the measured one; the measured number lies below the stated range.
By their numbers in this assay, from the lowest: compound 4; then compound 3; then compound 1; then compound 2.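

On the aromatic carbon next to the ring nitrogen and next to the ring sulfur, bromo in place of methyl gives a 3.2-fold lower number from compound 3 to compound 4 (0.51 log units; beyond the scatter) in this assay, the first step shown in which only one place in the molecule changes. This position on the five-membered aromatic ring is therefore not silent: exchanging one heavy atom for one, with no hydrogen-bond donors, hydrogen-bond acceptors or net charge on either side, is enough to carry the number beyond the scatter, towards a stronger inhibitor. No measurement at hand bears on the cause of this step.

This single step cannot tell whether the lower number is particular to bromo or would also appear with other groups on the same carbon, such as chloro, a nitrile, an amine or a longer alkyl chain. It also leaves open whether the same exchange would give a step of similar size and direction on a different core, or with the large group on the ring altered.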